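Trading a phenyl amide for a carboxyalkyl amide on a sulfated sugar

The compounds below may be only part of what the source reports. "The series", "measured", "known", "first", "only" and "open" are said of these compounds alone.

Measured compounds:
- compound 1, `CCN(CC(=O)NC[C@H]1O[C@H](OC)[C@@H](OS(=O)(=O)O)[C@@H](OS(=O)(=O)O)[C@@H]1OS(=O)(=O)O)C(=O)COS(=O)(=O)O`: 512000 nM
- compound 2, `CO[C@H]1O[C@H](CNC(=O)CN(C(C)=O)c2ccccc2)[C@@H](OS(=O)(=O)O)[C@H](OS(=O)(=O)O)[C@@H]1OS(=O)(=O)O`: 76000 nM

In an assay on isolated protein for binding affinity to vascular endothelial growth factor A, long form (Homo sapiens), read by surface plasmon resonance (on this read-out higher numbers stand for weaker binding and lower numbers for tighter binding), compound 1 gives 512000 nM and compound 2 gives 76000 nM. For the measured compounds named here, compound 2 therefore holds the lower of the two numbers, with compound 1 as its only neighbour, separated by the step of a 6.7-fold lower number from compound 1 to compound 2 (0.83 log units; beyond the scatter). Compound 3, `CCN(CC(=O)NC[C@H]1O[C@H](OC)[C@@H](OS(=O)(=O)O)[C@@H](OS(=O)(=O)O)[C@@H]1OS(=O)(=O)O)C(=O)CCCCC(=O)O`, has not been measured. It differs from compound 2 by ((4-carboxybutyl)carbonyl)(ethyl)amino in place of acetyl(phenyl)amino on a saturated chain carbon bound to a carbonyl carbon. Going by the values given here, the only measured step that bears on this change is a 6.7-fold lower number from compound 1 to compound 2 (0.83 log units; beyond the scatter), which accompanied the arrival of acetyl(phenyl)amino; compound 3 gives that group up again and returns to an ethyl-bearing amide nitrogen, as in compound 1, though with a different chain on the carbonyl. Much of the gain seen in that step is thus expected to be lost, and the step of a 3.3-fold higher number from compound 2 to compound 3 (0.52 log units; beyond the scatter) is expected to run toward weaker binding. Compound 3 is estimated at 250000 nM in this assay, within 80000 nM to 700000 nM.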

Compound 3, dissociation constant: 104000 nM
Compound 3: middle estimate off by 2.4-fold (0.38 log units), on the high side; measured number inside the range.
By their numbers in this assay, from the lowest: compounds 2 and 3 (each within the scatter of the next); then compound 1.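

In this assay, the step of a 1.4-fold higher number from compound 2 to compound 3 (0.14 log units; within the scatter) shows that acetyl(phenyl)amino is not required on this saturated chain carbon bound to a carbonyl carbon: ((4-carboxybutyl)carbonyl)(ethyl)amino, which has no ring, stands within the scatter of it. The step of a 4.9-fold lower number from compound 1 to compound 3 (0.69 log units; beyond the scatter) shows that, with the ethyl group on the amide nitrogen kept, 3-carboxypropyl in place of sulfooxy brings a change beyond the scatter, so a shift of this kind does not depend on a phenyl group. Nothing at hand explains either step. The compounds shown leave open whether the carboxylic acid at the chain end matters, as against a methyl ester or an amine there, and whether a shorter or longer chain would alter the number. They also leave open whether a phenyl group on the amide nitrogen would combine with the carboxylic acid chain.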